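The source may report more compounds than this note shows. Statements on the series, on what has been measured and on what is new or still open speak of the compounds shown alone.

Compound 1 `Fc1ccc(-c2nc3cnc(Nc4cc(C(F)(F)F)ccn4)cc3[nH]2)cc1F` gives >= 50000 nM in a physicochemical assay for solubility, using the shake flask method, in simulated intestinal fluid, measured as kinetic solubility, with a stated time of 20 h, at pH 6.5 (on this read-out higher numbers stand for higher solubility and lower numbers for lower solubility), as a limit of the assay and not a number.
Compound 2 `FC(F)(F)c1ccc(Nc2cc3[nH]c(C4CCOC4)nc3cn2)nc1` gives 180000 nM in this assay as a measured number.

Within the data shown here, compound 2, at 180000 nM here, is the only measured compound with a true number. Compound 3 `FC1(F)CC(c2nc3cnc(Nc4ccc(C(F)(F)F)cn4)cc3[nH]2)C1` differs from it by having 3,3-difluorocyclobutyl in place of oxolan-3-yl on an aromatic carbon and is otherwise the same. Among the measured compounds shown here, no measured step shows what such an exchange does. A moderate fall in this assay is expected, the estimated change being a 2.6-fold lower number from compound 2 to compound 3 (0.41 log units; beyond the scatter) in this reading. For compound 3 the expected value is 70000 nM with an estimated range from 15000 nM to 200000 nM in this assay.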

Compound 3, solubility: 161000 nM
Compound 3: middle estimate off by 2.3-fold (0.36 log units), on the low side; measured number inside the range.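

In this assay, 3,3-difluorocyclobutyl in place of oxolan-3-yl, on an aromatic carbon between two ring nitrogen atoms, gives a 1.1-fold lower number from compound 2 to compound 3 (0.05 log units; within the scatter). Among these compounds, this is the first measured step at this place. It stays within the scatter although the group that leaves carries a hydrogen-bond acceptor and the group that enters carries none. On these data alone, what an amine, a carboxylic acid or a longer chain at this place would give stays open. Compound 1 offers no number for this question, as it stands only as a limit of the assay: the limit of >= 50000 nM in this assay, at which 1 of the 3 values shown sits.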